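The compounds below may be only part of what the source reports. "The series", "measured", "known", "first", "only" and "open" are said of these compounds alone.

The three measured compounds share one core. Compound 1 `CC(C)COC(=O)Nc1ccc([Se]C#N)cc1` gives 31300 nM in a functional assay on HT-29 cells (Homo sapiens) for cytotoxicity, read by MTT assay, with a stated time of 72 h; on this read-out lower numbers stand for stronger inhibition of growth and higher numbers for weaker inhibition of growth. Compound 2 `N#C[Se]c1ccc(NC(=O)Oc2ccc(F)cc2)cc1` gives 37600 nM in this assay, and compound 3 `Cc1ccc(OC(=O)Nc2ccc([Se]C#N)cc2)cc1` gives 38800 nM in this assay. Compound 3 thus holds the highest of the three numbers, though its gap to compound 2 and its gap to compound 1 both lie within the scatter, so no order among the three can be read from them. For the measured compounds named here, the only step measured in one place, a 1.0-fold higher number from compound 2 to compound 3 (0.01 log units; within the scatter), exchanged one substituent for another at the same place and left the number essentially unchanged.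

Compound 4 `N#C[Se]c1ccc(NC(=O)Oc2ccccc2)cc1` differs from compound 3 by hydrogen in place of methyl on an aromatic carbon. Going by the values given here, no measured step removes a group at this place outright; the one step that touches it, a 1.0-fold higher number from compound 2 to compound 3 (0.01 log units; within the scatter), showed nothing beyond the scatter. On that basis the step of a 1.0-fold lower number from compound 3 to compound 4 (0.02 log units; within the scatter) is expected to remain within the scatter, with no clear direction. Compound 4 is therefore estimated at 37000 nM, with a range from 18000 nM to 75000 nM.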

Compound 4, concentration for total growth inhibition: 41700 nM
Beside the measured number, compound 4's estimate is 1.1-fold (0.05 log units) below it; the range from low to high includes it.
By their numbers in this assay, from the lowest: compounds 1, 2, 3 and 4 (each within the scatter of the next).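

With hydrogen on this aromatic carbon, para to a large group, the substituent is gone altogether, yet the number stays within the scatter: this assay gives a 1.1-fold higher number from compound 3 to compound 4 (0.03 log units; within the scatter), and against fluoro at the same place it gives a 1.1-fold higher number from compound 2 to compound 4 (0.04 log units; within the scatter). For the compounds shown here, the first comparison at a second place, on the oxygen next to a carbonyl group, is just as flat, with a 1.3-fold higher number from compound 1 to compound 4 (0.12 log units; within the scatter) for phenyl in place of isobutyl. No other measurement here helps to explain why these numbers stay so close.

From the compounds shown here alone, it remains open whether an amine or a carboxylic acid on this aromatic carbon would take the number beyond the scatter. The same question stands for a longer chain on the oxygen next to a carbonyl group.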